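A Trihydroxy Analogue: How Far Might the Number Fall?

A few compounds are considered here, and "the series" means these few. Any claim that something is new, unique, unknown or untested is made for them only; others in the source may bear on it.

Values measured in a physicochemical assay, read by spectrophotometry, with a stated time of 30 min; a higher number here means a weaker inhibitor, a lower number a stronger inhibitor
- compound 1 `O=C(CCc1nc2ccccc2c(=O)[nH]1)N/N=C/c1ccc(O)c(O)c1` gives 113000000 nM
- compound 2 `O=C(CCc1nc2ccccc2c(=O)[nH]1)N/N=C/c1ccc(O)cc1` gives 238000000 nM
- compound 3 `O=C(CCc1nc2ccccc2c(=O)[nH]1)N/N=C/c1ccccc1` gives 734000000 nM

Compound 3 has the highest number of the three, 734000000 nM, which makes it the weakest inhibitor of this small set. The next compound to be tested is compound 4 `O=C(CCc1nc2ccccc2c(=O)[nH]1)N/N=C/c1cc(O)c(O)c(O)c1`, which puts 3,4,5-trihydroxyphenyl in place of phenyl on a carbon with a double bond to nitrogen.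

The measured steps run the opposite way, from more hydroxy groups to fewer. Swapping a hydroxy for hydrogen gives a 2.1-fold higher number from compound 1 to compound 2 (0.32 log units; beyond the scatter), and a second such swap gives a 3.1-fold higher number from compound 2 to compound 3 (0.49 log units; beyond the scatter). Replacing the whole 3,4-dihydroxyphenyl group with phenyl gives a 6.5-fold higher number from compound 1 to compound 3 (0.81 log units; beyond the scatter). Among the measured compounds shown here, all three steps are modest but beyond the scatter, and no compound here goes against the trend. For the measured compounds named here, no compound with 3,4,5-trihydroxyphenyl has been measured yet, so this is an extrapolation.

Read in reverse, these steps point to a lower number in this assay, somewhat beyond compound 1. The expected change is a 15-fold lower number from compound 3 to compound 4 (1.17 log units; beyond the scatter). Compound 4 is therefore estimated at 50000000 nM, with an expected range from 15000000 nM to 150000000 nM.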

Compound 4, half-maximal inhibitory concentration: 81000000 nM
Compound 4: middle estimate off by 1.6-fold (0.21 log units), on the low side; low and high end bracket the measured number.
By their numbers in this assay, from the lowest: compounds 4 and 1 (each within the scatter of the next); then compound 2; then compound 3.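

In this assay the third hydroxy group keeps the ring well clear of bare phenyl, with 3,4,5-trihydroxyphenyl in place of phenyl giving a 9.1-fold lower number from compound 3 to compound 4 (0.96 log units; beyond the scatter) on a carbon with a double bond to nitrogen. The same group in place of 4-hydroxyphenyl gives a 2.9-fold lower number from compound 2 to compound 4 (0.47 log units; beyond the scatter) and so stays apart from the singly substituted ring as well. Among the compounds shown here, the newest addition, however, cannot be told apart from the scatter, as hydroxy in place of hydrogen on an aromatic carbon gives a 1.4-fold lower number from compound 1 to compound 4 (0.14 log units; within the scatter) and thus breaks the run of clear steps seen among the earlier compounds, showing that adding hydroxy groups here does not keep paying off in a measurable way.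

Still open, as far as these compounds go, is whether the effect belongs to hydroxy itself, which a ring bearing methoxy or an amine in the same places could test. Also open, from the compounds shown here alone, is whether a carboxylic acid on this ring would match the trihydroxy compound or move the number further, and the data offer no independent measurement that explains any of these steps.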